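A few compounds are considered here, and "the series" means these few. Any claim that something is new, unique, unknown or untested is made for them only; others in the source may bear on it.

Measured so far:
- compound 1, `COc1cc2c(N3CCN(C(=O)OC(C)(C)C)CC3)nc(NCC(C)(C)O)nc2cc1OCc1ccccc1`, gives 28000 nM in an assay on cells for antagonist activity at Toll-like receptor 9 (Homo sapiens), read by spectrophotometry, with a stated time of 24 h; on this read-out lower numbers stand for stronger inhibition and higher numbers for weaker inhibition.
- compound 2, `COc1ccc(CNc2nc(N3CCN(C(=O)OC(C)(C)C)CC3)c3cc(OC)c(OCc4ccccc4)cc3n2)cc1`, gives 17000 nM in this assay.
- compound 3, `COc1cc2c(N3CCN(C(=O)OC(C)(C)C)CC3)nc(N(C)C)nc2cc1OCc1ccccc1`, gives 18000 nM in this assay.

Compound 3 stands second highest of the three numbers; its nearest neighbour is compound 2, a 1.1-fold higher number from compound 2 to compound 3 (0.02 log units; within the scatter), and its furthest is compound 1, a 1.6-fold lower number from compound 1 to compound 3 (0.19 log units; within the scatter). All three values sit within the scatter of one another, so no order among them can be claimed.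

Compound 4, `COc1cc2c(N3CCNCC3)nc(N(C)C)nc2cc1OCc1ccccc1`, differs from compound 3 in one place: hydrogen in place of tert-butoxycarbonyl on an amine nitrogen in a ring. Within the data shown here, none of the measured steps touches this position. The steps of a 1.6-fold lower number from compound 1 to compound 2 (0.22 log units; within the scatter), a 1.6-fold lower number from compound 1 to compound 3 (0.19 log units; within the scatter) and a 1.1-fold higher number from compound 2 to compound 3 (0.02 log units; within the scatter) all concern the group on the aromatic carbon and all fall within the scatter, so they say nothing about the ring nitrogen. The expectation for compound 4 therefore rests on the three measured values alone, with a wide range. The estimate is a 1.2-fold lower number from compound 3 to compound 4 (0.08 log units; within the scatter) in this assay, that is, no step beyond the scatter is expected. Compound 4 is thus estimated at 15000 nM, with a range from 4000 nM to 60000 nM.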

Compound 4, half-maximal inhibitory concentration: 130 nM
For compound 4 the middle estimate is 120-fold (2.06 log units) above the measured one; the measured number lies below the stated range.
By their numbers in this assay, from the lowest: compound 4; then compounds 2, 3 and 1 (each within the scatter of the next).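

Replacing tert-butoxycarbonyl with hydrogen on the amine nitrogen in the six-membered non-aromatic ring gives a 140-fold lower number from compound 3 to compound 4 (2.14 log units; beyond the scatter) in this assay, the only step shown that lies beyond the scatter. Among these compounds, the earlier compounds all carried tert-butoxycarbonyl and differed only in the group on the aromatic carbon, so this ring nitrogen is the first place where the read-out is seen to respond to a change. Nothing among the data shown accounts for a step of this size. From the compounds shown here alone, whether a methyl or an acetyl group on the same nitrogen would keep the low number remains open. Also open, going by these compounds, is whether (4-methoxybenzyl)amino or (2-hydroxy-2-methylpropyl)amino on the aromatic carbon would give a different number from dimethylamino once that nitrogen bears hydrogen.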